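A few compounds are considered here, and "the series" means these few. Any claim that something is new, unique, unknown or untested is made for them only; others in the source may bear on it.

Compound 1 `CC(C)NCC(=O)NCC(=O)N(C)c1ccc(Cl)cc1C(=O)c1ccccc1Cl`: 1 mg/kg
Compound 2 `NCC(=O)NCC(=O)Nc1ccc([N+](=O)[O-])cc1C(=O)c1ccccc1`: 4.82 mg/kg
Compound 3 `NC(C(=O)NCC(=O)Nc1ccc(Cl)cc1C(=O)c1ccccc1)c1ccccc1`: 28 mg/kg

Among the three measured compounds, compound 1 gives the lowest number in a functional assay on the whole organism for antagonist activity, with Mus musculus as the target; on this read-out higher numbers stand for an effect only at larger amounts of compound and lower numbers for an effect already at smaller amounts; compound 2 gives a higher value, and compound 3 a higher one still, both gaps beyond the scatter. Compound 4 `CN(C(=O)CNC(=O)CN)c1ccc(Cl)cc1C(=O)c1ccccc1Cl` differs from compound 1 in one place: hydrogen in place of isopropyl on an amine nitrogen. The change reads as isopropylamino to amino on an amine nitrogen whose other neighbour is a saturated chain carbon. For the measured compounds named here, no measured pair shows this exact change, so its size is uncertain. Compounds 2 and 3 both carry an amino group and give higher numbers than compound 1, but they differ from it elsewhere as well. The step of a 2.5-fold higher number from compound 1 to compound 4 (0.40 log units; beyond the scatter) is expected to be modest, around the edge of the scatter. The estimate for compound 4 is 2.5 mg/kg, within 0.8 mg/kg to 8 mg/kg.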

Compound 4, dose for half-maximal effect: 0.58 mg/kg
Compound 4: the middle estimate sits 4.3-fold (0.63 log units) above what was measured, outside the stated range (below it).
By their numbers in this assay, from the lowest: compounds 4 and 1 (each within the scatter of the next); then compound 2; then compound 3.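

Hydrogen in place of isopropyl on this amine nitrogen gives a 1.7-fold lower number from compound 1 to compound 4 (0.24 log units; within the scatter) in this assay, so compound 1 and compound 4 cannot be told apart on this read-out. On the core of compound 1, the isopropyl group is therefore not required for an effect at small amounts, and the plain amino group serves equally well. No measurement at hand accounts for this result. The compounds shown leave open how a methyl group, a longer chain or a cyclohexyl group on this nitrogen would read. They also leave open whether an acetyl group there would keep the effect.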